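Benzyl ether in place of the sulfonate of compound 3

A few compounds are considered here, and "the series" means these few. Any claim that something is new, unique, unknown or untested is made for them only; others in the source may bear on it.

Compound 1 `Oc1cc(-c2ccccc2)nc2c(O)cccc12`, compound 2 `CCCCOc1cc(-c2ccccc2)nc2ccccc12` and compound 3 `CS(=O)(=O)Oc1cc(-c2ccccc2)nc2ccccc12` share one core and differ at the oxygen on the aromatic ring. In a functional assay on HCT-8 cells (Homo sapiens) for cytotoxicity (a higher number here means that more compound is needed for the effect, a lower number that less compound is needed), compound 1 gives only the limit > 10 ug/mL, not a number. In this assay compound 2 likewise gives the limit > 10 ug/mL. In this assay compound 3 gives 5.6 ug/mL. Going by the values given here, compound 3 is thus the only compound with a number; the two others sit at the limit of > 10 ug/mL in this assay, at which 2 of the 3 values shown sit. Among the compounds with values here, the one step between measured neighbours is an at least 1.7-fold lower number from compound 2 to compound 3 (0.25 log units; that floor lies within the scatter).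

Compound 4 `c1ccc(COc2cc(-c3ccccc3)nc3ccccc23)cc1` is unmeasured. It differs from compound 3 in that (benzyl in place of methylsulfonyl on an oxygen on an aromatic ring). The benzyl group is, like the butyl group of compound 2, a carbon-only substituent on the oxygen, so the step from compound 2 to compound 3 is the only one that bears on this change, and it runs in the opposite direction. That step was a small lowering of the number at most, with its floor inside the scatter, so only a modest rise of the number is expected for compound 4 in this assay, with a fair chance that only the limit is reached. For compound 4 the estimated step is a 1.6-fold higher number from compound 3 to compound 4 (0.21 log units; within the scatter). Compound 4 is expected to give about 9 ug/mL in this assay, within 4 ug/mL to 20 ug/mL.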

Compound 4, half-maximal effective concentration: > 10 ug/mL
Compound 4 ended at the assay's limit; the forecaster's own chance of this, stated with the estimate: 50%; at least 1.1-fold (0.04 log units) between middle value and limit.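

The change to benzyl gives an at least 1.7-fold higher number from compound 3 to compound 4 (0.25 log units; that floor lies within the scatter) in this assay. Going by these compounds alone, at the oxygen on the aromatic ring, benzyl thus joins butyl as a second carbon-only substituent at the limit of the assay, and the methylsulfonyl of compound 3 remains the only group at this position with a readable number, although the floor of the step lies within the scatter. The step from compound 2 to compound 4, phenyl in place of propyl on a saturated chain carbon, cannot be read, so the two ethers cannot be ranked, and the series now rests mostly on a single limit: the limit of > 10 ug/mL in this assay, at which 3 of the 4 values shown sit.

From the compounds shown here alone, it remains open whether the number of compound 3 is specific to a sulfonate on this oxygen or would also appear with an acetyl ester, a benzenesulfonyl group or an aminoethyl chain. Going by these compounds, how far compound 2 and compound 4 actually lie from compound 3 also stays open, and a real difference from the sulfonate would need numbers in place of limits.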